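Ether-linked dimethoxy side chain on the shared core

The source may hold more compounds than are shown below. What is called first, only, known or untested is meant among the compounds shown, and "the series" means these compounds.

For the measured compounds named here, compound 3 `CCCCC(CCCC)Nc1nc(C)nc2c1nnn2-c1ccc(C(C)C)cc1Br` gives 4.5 nM in an in vitro assay on 293-EBNA cells for binding affinity to corticotropin-releasing factor receptor 1 (Homo sapiens) (on this read-out lower numbers stand for stronger inhibition and higher numbers for weaker inhibition), the lowest of the three numbers measured so far. Compound 1 `CCN(c1nc(C)nc2c1nnn2-c1ccc(C(C)C)cc1Br)C(COC)COC` gives 123 nM, and compound 2 `COCCCNc1nc(C)nc2c1nnn2-c1ccc(C(C)C)cc1Br` gives 291 nM. The step of a 27-fold lower number from compound 1 to compound 3 (1.44 log units; beyond the scatter) and the step of a 65-fold lower number from compound 2 to compound 3 (1.81 log units; beyond the scatter) both show that the 1-butylpentylamino substituent on the shared core sits well ahead of the methoxy-bearing side chains, and a 2.4-fold higher number from compound 1 to compound 2 (0.37 log units; beyond the scatter) shows the two methoxy-bearing chains differing only modestly from each other.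

Compound 4 `COCC(COC)Oc1nc(C)nc2c1nnn2-c1ccc(C(C)C)cc1Br` carries a group of 8 heavy atoms (5 carbon, 3 oxygen; no ring) in place of a group of 10 heavy atoms (9 carbon, 1 nitrogen; no ring), on an aromatic carbon. Going by the values given here, the entering group is the same dimethoxy-substituted three-carbon unit found in compound 1, now attached through oxygen and without the ethyl of compound 1; no measured compound shows an oxygen-linked side chain, so this part of the change is untested. The two large steps toward compound 3 both bear on it and point to a clear loss. For compound 4 an affinity near that of compound 1 is expected, the step of a 33-fold higher number from compound 3 to compound 4 (1.52 log units; beyond the scatter) being estimated, giving an expected 150 nM with a range from 40 nM to 600 nM in this assay.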

Compound 4, inhibition constant: 7.1 nM
Compound 4: the middle estimate sits 21-fold (1.32 log units) above what was measured; measured number outside the range, below it.
By their numbers in this assay, from the lowest: compounds 3 and 4 (each within the scatter of the next); then compound 1; then compound 2.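

Methoxy-bearing chains are not tied to weak numbers on this aromatic carbon: in this assay the step of a 1.6-fold higher number from compound 3 to compound 4 (0.20 log units; within the scatter) puts the oxygen-linked chain level with 1-butylpentylamino, so compound 4 goes against the pattern that compounds 1 and 2 suggested. The large steps of a 17-fold lower number from compound 1 to compound 4 (1.24 log units; beyond the scatter) and a 41-fold lower number from compound 2 to compound 4 (1.61 log units; beyond the scatter) show that the way the chain is attached and its shape at this place can outweigh the mere presence of methoxy groups. No evidence at hand explains these steps.

The step from compound 1 joins the swap of nitrogen for oxygen with the loss of the ethyl, and the shared dimethoxy unit on a nitrogen bearing hydrogen would be needed to part the two. Also open, from the compounds shown here alone, is how a 1-butylpentyl chain attached through oxygen, or a hydroxyl in place of each methoxy, would read here.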